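A methyl added to the amine of compound 3

The compounds below may be only part of what the source reports. "The series", "measured", "known", "first", "only" and "open" are said of these compounds alone.

Compound 1 `CN(C)c1ncnc2c1c(-c1ccoc1)cn2[C@@H]1O[C@H](CO)[C@@H](O)[C@H]1O`: 1540 nM
Compound 2 `Cc1ncnc2c1c(-c1cccs1)cn2[C@@H]1O[C@H](CO)[C@@H](O)[C@H]1O`: > 20000 nM
Compound 3 `CNc1ncnc2c1c(-c1cccs1)cn2[C@@H]1O[C@H](CO)[C@@H](O)[C@H]1O`: > 20000 nM

In a functional assay on K562 cells (Homo sapiens), read by MTT assay, with a stated time of 72 h (a lower number here means a stronger inhibitor, a higher number a weaker inhibitor), compound 1 gives 1540 nM. Compound 2 reaches only the limit of the assay, > 20000 nM. Compound 3 also reaches only that limit, > 20000 nM, so its true value is not known. The step that the two limits leave unreadable from compound 2 to compound 3 therefore cannot be read. Compound 4 `CN(C)c1ncnc2c1c(-c1cccs1)cn2[C@@H]1O[C@H](CO)[C@@H](O)[C@H]1O` differs from compound 3 by methyl in place of hydrogen on a nitrogen on an aromatic ring, that is methylamino to dimethylamino. For the measured compounds named here, no measured step covers this change; compound 1 carries the dimethylamino group and shows a number, not a limit, (the limit of > 20000 nM in this assay, at which 2 of the 3 values shown sit). On that slender basis compound 4 is expected to be an at least 3.3-fold lower number from compound 3 to compound 4 (0.52 log units; beyond the scatter), giving an estimate of 6000 nM with a range from 1200 nM to 30000 nM.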

Compound 4, half-maximal inhibitory concentration: > 20000 nM
Compound 4 gave a limit, no number; the forecaster's own chance of this, stated with the estimate: 35%; middle value at least 3.3-fold (0.52 log units) from the limit.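

In this assay compound 4 gives only a limit, > 20000 nM. The steps to compound 4 from compound 2 and compound 3 cannot be read, because each pair has a limit at both ends: the limit of > 20000 nM in this assay, at which 3 of the 4 values shown sit.

With dimethylamino kept, thiophen-2-yl in place of furan-3-yl gives an at least 12-fold higher number from compound 1 to compound 4 (1.11 log units; beyond the scatter), so on this pair the dimethylamino group alone does not bring a measurable number, and the group on the aromatic carbon makes a large difference.

From the compounds shown here alone, the true order of the thiophen-2-yl compounds stays unknown. Going by these compounds, it is also open whether a phenyl group on that carbon, or furan-3-yl paired with methylamino, would give a number.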